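Methylating the ring nitrogen of the shared core

The compounds below may be only part of what the source reports. "The series", "measured", "known", "first", "only" and "open" are said of these compounds alone.

Compound 1 `COc1ccc(-c2cc3[nH]nc(N)c3c(=O)[nH]2)cc1` gives 21% in an assay on isolated protein for inhibition of RAC-alpha serine/threonine-protein kinase (Homo sapiens), read by mobility shift assay, tested at 30 uM; a lower number here means less inhibition, a higher number more inhibition at the concentration tested (going by the name of the read-out).
Compound 2 `CN1CCN(c2ccc(-c3cc4[nH]nc(N)c4c(=O)[nH]3)cc2)CC1` gives 9%.

Compound 1 stands highest of the two measured numbers; its nearest neighbour is compound 2, with a step of a number 12 percentage points lower from compound 1 to compound 2 (beyond the scatter). Compound 3 `COc1ccc(-c2cc3c(c(N)nn3C)c(=O)[nH]2)cc1` has not been measured. It differs from compound 1 by methyl in place of hydrogen on an aromatic nitrogen. Going by the values given here, no measured step touches this ring nitrogen, so the one known step gives no guide to its effect. The expected change is therefore small, a step of a number 9 percentage points lower from compound 1 to compound 3 (within the scatter) from compound 1, and compound 3 is estimated at 12%, between -5% and 30%.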

Compound 3, a percentage reported as inhibition, at one concentration (the size of the read-out at that concentration, not a potency): 9%
Beside the measured number, compound 3's estimate is 3 percentage points above it, within the range that was stated.
By their numbers in this assay, from the lowest: compounds 2 and 3 (each within the scatter of the next); then compound 1.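

Methyl in place of hydrogen on the aromatic nitrogen gives a number 12 percentage points lower from compound 1 to compound 3 (beyond the scatter) in this assay and so shows that this nitrogen of the shared core is sensitive to change. Even a single added carbon moves the number here, whereas the earlier step concerned only the group on the aromatic carbon.

On these data alone, whether an ethyl group or a longer chain on this nitrogen would lower the number further stays open, as does the effect of a chain ending in an amine. Nothing measured here gives a reason for the drop.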